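This account rests on a few compounds, and the source may have more. Where it says the series, first, only, none or still open, it means among the compounds named here.

Measured in a functional assay on L1210 cells (Mus musculus) for inhibition, with a stated time of 48 h; a lower number here means a stronger inhibitor, a higher number a weaker inhibitor:
- compound 1 `CC[C@H](C)[C@H](NC(=O)OC(C)(C)C)C(=O)N(Cc1ccccc1)C1(C(=O)NCc2ccccc2)CCN(Cc2ccccc2)CC1`: 4400 nM
- compound 2 `CC(C)(C)OC(=O)N[C@@H](CC(=O)O)C(=O)N(Cc1ccccc1)C1(C(=O)NCc2ccccc2)CCN(Cc2ccccc2)CC1`: 164000 nM

Of these two compounds, compound 2 stands highest, at 164000 nM. Compound 3 `CNC(=O)C[C@H](NC(=O)OC(C)(C)C)C(=O)N(Cc1ccccc1)C1(C(=O)NCc2ccccc2)CCN(Cc2ccccc2)CC1` is unmeasured and differs from it at a single place: methylamino in place of hydroxy on a carbonyl carbon. This puts methylamino in place of hydroxy on a carbonyl carbon, so carboxymethyl becomes (methylcarbamoyl)methyl.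

Among the measured compounds shown here, only one measured step bears on this change: a 37-fold higher number from compound 1 to compound 2 (1.57 log units; beyond the scatter), a large step with carboxymethyl in place of sec-butyl. For the measured compounds named here, it involves the same carboxymethyl group, but no measured step tests the exchange of hydroxy itself. With compound 1 at 4400 nM marking the low side, a moderate step to a lower number is expected in this assay, smaller than the measured one. The expected change is a 4.1-fold lower number from compound 2 to compound 3 (0.61 log units; beyond the scatter). For compound 3 the estimated value is 40000 nM, with an expected range from 10000 nM to 150000 nM.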

Compound 3, half-maximal inhibitory concentration: 94000 nM
The estimate for compound 3 lay 2.4-fold (0.37 log units) below the measured number; measured number inside the range.
By their numbers in this assay, from the lowest: compound 1; then compounds 3 and 2 (each within the scatter of the next).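

In this assay, methylamino in place of hydroxy on this carbonyl carbon gives a 1.7-fold lower number from compound 2 to compound 3 (0.24 log units; within the scatter), so at this position compound 3 cannot be told apart from compound 2. Measured against sec-butyl, (methylcarbamoyl)methyl still gives a 21-fold higher number from compound 1 to compound 3 (1.33 log units; beyond the scatter), which shows that the large step to a higher number is not confined to the carboxy form of this chain and remains with methylcarbamoyl in its place. Nothing given here explains either step.

The compounds shown leave open whether the large step belongs to the carbonyl at the end of this chain or to the replacement of sec-butyl in general. An isobutyl group, a primary amine or a longer chain ending in a carboxylic acid, placed on the same saturated chain carbon, would bear on that question.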